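A few compounds are considered here, and "the series" means these few. Any claim that something is new, unique, unknown or untested is made for them only; others in the source may bear on it.

Of the compounds shown here, three have so far been measured in a functional assay on L1210 cells (Mus musculus) for inhibition; on this read-out lower numbers stand for stronger inhibition and higher numbers for weaker inhibition. Compound 1 `C=CCN(Cc1ccc2nc(C)[nH]c(=O)c2c1)c1ccc(C(=O)N[C@@H](CCC(=O)O)C(=O)O)cc1` gives 170 nM. Compound 2 `Cc1nc2ccc(CN(CCN)c3ccc(C(=O)N[C@@H](CCC(=O)O)C(=O)O)c(F)c3)cc2c(=O)[nH]1` gives 2700 nM, and compound 3 `Cc1nc2ccc(CN(CC(N)=O)c3ccc(C(=O)N[C@@H](CCC(=O)O)C(=O)O)c(F)c3)cc2c(=O)[nH]1` gives 800 nM. Compound 3 therefore stands second highest of the three: compound 2 lies beyond the scatter above it, and compound 1 lies beyond the scatter below it. Among the measured compounds shown here, the only measured step, a 3.4-fold lower number from compound 2 to compound 3 (0.53 log units; beyond the scatter), came from carbamoyl in place of aminomethyl on a saturated chain carbon bound to a nitrogen on an aromatic ring.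

Compound 4 `C=CCN(Cc1ccc2nc(C)[nH]c(=O)c2c1)c1ccc(C(=O)N[C@@H](CCC(=O)O)C(=O)O)c(F)c1` has not been measured. It differs from compound 3 in one place: vinyl in place of carbamoyl on a saturated chain carbon bound to a nitrogen on an aromatic ring. For the measured compounds named here, no measured step covers this exchange directly, so the guide is compound 1, which carries the same allyl group and differs from compound 4 only by a single fluorine atom; in this assay compound 1 gives 170 nM. Because compound 3 sits at 800 nM while compound 1 sits at 170 nM, a step downward is expected. The expected step is a 4.0-fold lower number from compound 3 to compound 4 (0.60 log units; beyond the scatter). Compound 4 is estimated at 200 nM, within a range from 80 nM to 500 nM.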

Compound 4, half-maximal inhibitory concentration: 100 nM
Compound 4: the middle estimate sits 2.0-fold (0.30 log units) above what was measured, and the stated range covers the measured number.
By their numbers in this assay, from the lowest: compounds 4 and 1 (each within the scatter of the next); then compound 3; then compound 2.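

In this assay, the group on the saturated chain carbon bound to a nitrogen on an aromatic ring now shows a much wider reach: vinyl in place of carbamoyl gives an 8.0-fold lower number from compound 3 to compound 4 (0.90 log units; beyond the scatter) and vinyl in place of aminomethyl gives a 27-fold lower number from compound 2 to compound 4 (1.43 log units; beyond the scatter) in a series that keeps the fluorine, so the exchange at this one place spans a modest to a large step. Among the compounds shown here, the allyl pair also gives the first reading of fluoro in place of hydrogen on an aromatic carbon, and a 1.7-fold lower number from compound 1 to compound 4 (0.23 log units; within the scatter) shows that this change leaves no readable difference here, whereas the chain group clearly does. Nothing at hand explains why these groups rank as they do.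

As far as these compounds go, whether the double bond of the allyl group matters stays open, and a saturated propyl chain or a propargyl group, with its carbon-carbon triple bond, at this place would test that. From the compounds shown here alone, the fluorine reading also rests on the allyl pair alone, so how it behaves alongside carbamoylmethyl or aminoethyl remains unknown.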